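Hydroxy for Hydrogen on the Benzyl of Compound 3

The compounds below may be only part of what the source reports. "The series", "measured", "known", "first", "only" and "open" are said of these compounds alone.

Compound 3 `Cc1ccc(CN2C(=O)CC[C@H]2C(=N)NCc2ccccc2)cc1` gives 17.1% in a functional assay on SH-SY5Y cells (Homo sapiens) for cytotoxicity, read by MTT assay, with stated times of 8 h, 30 min and 12 h, tested at 0.05 uM (on this read-out lower numbers stand for a weaker effect and higher numbers for a stronger effect at the one concentration tested), the lowest of the three numbers; compound 1 `N=C(NCc1ccc(O)cc1)[C@@H]1CCC(=O)N1Cc1ccccc1` gives 19.8%, which lies within the scatter of it, while compound 2 `N=C(NCc1ccc(O)cc1)[C@@H]1CCC(=O)N1Cc1ccc(F)cc1` gives 35.2%, beyond the scatter. Compound 4 `Cc1ccc(CN2C(=O)CC[C@H]2C(=N)NCc2ccc(O)cc2)cc1` differs from compound 3 by hydroxy in place of hydrogen on an aromatic carbon. For the measured compounds named here, the only measured step, a number 15.4 percentage points higher from compound 1 to compound 2 (beyond the scatter), concerns a different group and so does not bear directly on this change. Compound 1, which carries the same hydroxy group, and compound 3 show values within the scatter of each other. Compound 4 is therefore expected to move by a number 3.9 percentage points higher from compound 3 to compound 4 (within the scatter), no step beyond the scatter. The estimate for compound 4 is 21%, within 10% to 34%.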

Compound 4, a percentage reported as activity, at one concentration (the size of the read-out at that concentration, not a potency): 20.5%
The estimate for compound 4 lay 0.5 percentage points above the measured number; the measured number falls inside the stated range.
By their numbers in this assay, from the lowest: compounds 3, 1 and 4 (each within the scatter of the next); then compound 2.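

In this assay, the change from phenyl to 4-hydroxyphenyl gives a number 3.4 percentage points higher from compound 3 to compound 4 (within the scatter) and so leaves the number unmoved when methyl sits on the other benzyl group. With the hydroxy present, methyl in place of hydrogen gives a number 0.7 percentage points higher from compound 1 to compound 4 (within the scatter) and methyl in place of fluoro gives a number 14.7 percentage points lower from compound 2 to compound 4 (beyond the scatter) on that other benzyl group, so only the fluoro compound stands apart. Nothing available bears on the cause of these results. From the compounds shown here alone, whether an amine or a carboxylic acid at the hydroxy position would shift the number remains open. So does whether the hydroxy matters when fluoro occupies the other benzyl group.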